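Dropping the chloro group from compound 3

This account rests on a few compounds, and the source may have more. Where it says the series, first, only, none or still open, it means among the compounds named here.

In a functional assay on OVCAR-3 cells (Homo sapiens) for inhibition, read by MTT assay, with a stated time of 24 h (on this read-out higher numbers stand for weaker inhibition and lower numbers for stronger inhibition), compound 3 `CC1(C)[C@H]2CC[C@]1(C)N(Cc1cn(-c3ccccc3Cl)nn1)C(=O)C2` gives 40 nM, the lowest of the three numbers. Compound 1 `CC1(C)[C@H]2CC[C@]1(C)N(Cc1cn(-c3ccccc3C#N)nn1)C(=O)C2` gives 110 nM and compound 2 `CC1(C)[C@H]2CC[C@]1(C)N(Cc1cn(-c3cccc(C#N)c3)nn1)C(=O)C2` gives 230 nM. Compound 4 `CC1(C)[C@H]2CC[C@]1(C)N(Cc1cn(-c3ccccc3)nn1)C(=O)C2` has hydrogen in place of chloro on an aromatic carbon, ortho to a large group: hydrogen in place of chloro on an aromatic carbon. For the measured compounds named here, no measured step removes a group outright. The closest is a 2.8-fold lower number from compound 1 to compound 3 (0.44 log units; beyond the scatter), a modest change at the same place, while a 2.1-fold higher number from compound 1 to compound 2 (0.32 log units; beyond the scatter) and a 5.8-fold lower number from compound 2 to compound 3 (0.76 log units; beyond the scatter) are also modest. In this assay, a modest rise in the number is therefore expected on losing the chloro group. The expected step is a 2.8-fold higher number from compound 3 to compound 4 (0.44 log units; beyond the scatter). For compound 4 the estimate is 110 nM, with an expected range of 45 nM to 280 nM.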

Compound 4, half-maximal inhibitory concentration: 50 nM
The estimate for compound 4 lay 2.2-fold (0.34 log units) above the measured number; measured number inside the range.
By their numbers in this assay, from the lowest: compounds 3 and 4 (each within the scatter of the next); then compound 1; then compound 2.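

In this assay, chloro on this aromatic carbon, ortho to a large group, can be replaced by hydrogen with no change beyond the scatter (a 1.3-fold higher number from compound 3 to compound 4 (0.10 log units; within the scatter)). The parent phenyl thus stands apart from the cyano compounds, with hydrogen in place of cyano giving lower numbers (a 2.2-fold lower number from compound 1 to compound 4 (0.34 log units; beyond the scatter); a 4.6-fold lower number from compound 2 to compound 4 (0.66 log units; beyond the scatter)). Nothing available explains these differences.

Open, from the compounds shown here alone, is whether a methoxy group or an amine at this place would stay level with chloro and hydrogen or behave like cyano.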